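Oxetane-bearing amine on the shared core: tolerance on cells

A few compounds are considered here, and "the series" means these few. Any claim that something is new, unique, unknown or untested is made for them only; others in the source may bear on it.

Three compounds have been examined in an ADME assay on HEp-2 cells (Homo sapiens) for cytotoxicity, read by CCK-8 assay, with a stated time of 5 days; a lower number here means that less compound is tolerated, a higher number that more compound is tolerated. Compound 1 `NCCCCNc1cc(N2CCc3ccccc3C2)nc2ccccc12` gives 7400 nM. Compound 2 `NCCNc1cc(N2CCCc3ccccc3C2)nc2c(Cl)cccc12` gives 25000 nM. Compound 3 `Cc1ccc2nc(N3CCCc4ccc(F)cc4C3)cc(NCC(C)(C)N)c2c1` gives 23000 nM, which is the second highest of the three numbers; its nearest neighbour is compound 2, whose number is within the scatter of it, while compound 1 stands furthest away with a lower number that lies beyond the scatter.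

Compound 4 `Cc1ccc2nc(N3CCCc4ccc(F)cc4C3)cc(NC3(CN)COC3)c2c1` has not been measured. It differs from compound 3 by 3-(aminomethyl)oxetan-3-yl in place of 2-amino-2-methylpropyl on a nitrogen on an aromatic ring; cut one bond further out, the change reads (2-amino-2-methylpropyl)amino to (3-(aminomethyl)oxetan-3-yl)amino. Going by the values given here, no pair among the measured compounds shows this kind of change, so nothing in the data sets the size of the step. The expectation for this assay is therefore a small movement, if any, toward a higher number, most likely not beyond the scatter, a step of a 1.3-fold higher number from compound 3 to compound 4 (0.12 log units; within the scatter) being what is estimated. On that basis compound 4 is expected to give about 30000 nM in this assay, with a likely range from 12000 nM to 70000 nM.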

Compound 4, half-maximal cytotoxic concentration: 86000 nM
Compound 4: middle estimate off by 2.9-fold (0.46 log units), on the low side; measured number above the stated range.
By their numbers in this assay, from the lowest: compound 1; then compounds 3 and 2 (each within the scatter of the next); then compound 4.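

In this assay, putting 3-(aminomethyl)oxetan-3-yl in place of 2-amino-2-methylpropyl on a nitrogen on an aromatic ring gives a 3.7-fold higher number from compound 3 to compound 4 (0.57 log units; beyond the scatter), while the rest of the structure stays the same. Going by these compounds alone, this is the first comparison in the set in which only one place differs, and it shows that this position is not silent in this assay: a change confined to the group on that nitrogen is enough to move the number beyond the scatter, and it moves it toward more compound being tolerated. Nothing available here bears on what lies behind the step.

The compounds shown do not separate the contribution of the four-membered ring from that of its oxygen, a question that a cyclobutane carrying the same aminomethyl group on that nitrogen would address, and an azetidine would test a ring nitrogen in the same place. Also open is whether this exchange moves the number in the same direction and by a similar size on the other cores shown, or whether the step belongs to the core of compound 3 alone.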